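A Dichlorophenyl Swap at the Cytotoxicity Limit

This account rests on a few compounds, and the source may have more. Where it says the series, first, only, none or still open, it means among the compounds named here.

In an ADME assay on HepG2 cells (Homo sapiens) for cytotoxicity, read by CellTiter-Glo and resazurin assay, with a stated time of 72 h (on this read-out higher numbers stand for an effect only at larger amounts of compound and lower numbers for an effect already at smaller amounts), compound 1 (`CC(C)N(Cc1cccc(OCCCCCC(=O)O)c1)C(=O)c1ccc(-c2cccc(O)c2)cc1`) gives > 26000 nM as a limit of the assay. Compound 2 (`CC(C)N(Cc1cccc(OCCCCCC(=O)O)c1)C(=O)c1ccc(-c2c[nH]c3ccccc23)cc1`) gives > 26000 nM and this is also a limit, so compound 2 has no exact number.

3,4-dichlorophenyl in place of 1H-indol-3-yl on an aromatic carbon is the change that leads to compound 3 (`CC(C)N(Cc1cccc(OCCCCCC(=O)O)c1)C(=O)c1ccc(-c2ccc(Cl)c(Cl)c2)cc1`) and it puts 3,4-dichlorophenyl in place of 1H-indol-3-yl on an aromatic carbon, para to a large group. Among the compounds with values here, the one measured step that bears on it is a step that the two limits leave unreadable from compound 1 to compound 2 and it changes the group on an aromatic carbon without giving a size. Within the data shown here, the only guide is therefore the limit of > 26000 nM in this assay, at which 2 of the 2 values shown sit, and it fixes no size for a new step. The estimated change is an at least 1.1-fold lower number from compound 2 to compound 3 (0.07 log units; that floor lies within the scatter) and any expected move in this assay is toward lower numbers. For compound 3 the expected value is 22000 nM with an estimated range from 8000 nM to 40000 nM and another limit is quite possible.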

Compound 3, half-maximal effective concentration: > 26000 nM
Compound 3: no number, only a limit; the forecaster's own chance of this, stated with the estimate: 60%; middle value at least 1.1-fold (0.07 log units) away from the limit.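

In this assay compound 3 gives > 26000 nM, again a limit and not a number, so no step among compound 1, compound 2 and compound 3 can be read: the limit of > 26000 nM in this assay, at which 3 of the 3 values shown sit.

The compounds shown leave open how these three groups would rank on this read-out, and whether any group at this aromatic carbon would give an exact number.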